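Swapping the fluorobenzyl arm for a chlorophenyl urea

The compounds below may be only part of what the source reports. "The series", "measured", "known", "first", "only" and "open" are said of these compounds alone.

compound 1 `NC(=O)c1c(NC(=O)c2ccccc2Cl)sc2c1CCN(Cc1ccccc1F)C2`: in a functional assay on HeLa cells (Homo sapiens) for antiproliferative activity, with a stated time of 24 h (a lower number here means a stronger inhibitor, a higher number a weaker inhibitor), compound 1 gives > 50000 nM, which is a limit of the assay
compound 2 `NC(=O)c1c(NC(=O)c2ccc(C(F)(F)F)cc2)sc2c1CCN(Cc1ccccc1F)C2`: in this assay compound 2 gives > 50000 nM, which is a limit of the assay
compound 3 `NC(=O)c1c(NC(=O)c2ccccc2F)sc2c1CCN(C(=S)Nc1ccccc1Cl)C2`: in this assay compound 3 gives 19400 nM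

Compound 2 sits at the limit of > 50000 nM in this assay, at which 2 of the 3 values shown sit, so the numbers give only a bound for it, not a value. Among the measured compounds shown here, the one measured step, a step that the two limits leave unreadable from compound 1 to compound 2, runs between two limits and its size cannot be read. Compound 4 `NC(=O)c1c(NC(=O)c2ccc(C(F)(F)F)cc2)sc2c1CCN(C(=O)Nc1ccccc1Cl)C2` differs from compound 2 by (2-chlorophenyl)carbamoyl in place of 2-fluorobenzyl on an amine nitrogen in a ring. For the measured compounds named here, no measured step covers this change; compound 3, the only compound with a number, carries a different arm on the same nitrogen. Compound 4 is therefore expected to stay weak, with an estimate of 40000 nM and a range from 10000 nM to 60000 nM. The expected step of an at least 1.2-fold lower number from compound 2 to compound 4 (0.09 log units; that floor lies within the scatter) cannot be set against a limit with confidence.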

Compound 4, half-maximal inhibitory concentration: > 50000 nM
Compound 4 was reported as a limit; the forecaster's own chance of this, stated with the estimate: 55%; middle value at least 1.2-fold (0.09 log units) from the limit.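

In this assay compound 4 gives > 50000 nM, which is a limit of the assay. Compound 2 also sits at a limit, so the step between compound 2 and compound 4 cannot be read. The compounds shown leave open whether (2-chlorophenyl)carbamoyl in place of 2-fluorobenzyl changes activity at all.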